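Pyrazolyl enone series: aryl ketone replacement in compound 1

The compounds below may be only part of what the source reports. "The series", "measured", "known", "first", "only" and "open" are said of these compounds alone.

Measured compounds:
compound 1, `COc1cc(-c2cc(/C=C/C(=O)c3ccc(N)cc3)[nH]n2)cc(OC)c1OC` — 1300 nM
compound 2, `COc1ccc(-c2cc(/C=C/C(=O)c3ccc(N)cc3)[nH]n2)cc1OC` — 1730 nM
compound 3, `COc1ccc(-c2cc(/C=C/C(=O)c3cc(OC)c(OC)c(OC)c3)[nH]n2)cc1OC` — 300 nM

In a functional assay on SF-539 cells (Homo sapiens) for inhibition, read by sulforhodamine B assay, with a stated time of 48 h (on this read-out higher numbers stand for weaker inhibition of growth and lower numbers for stronger inhibition of growth), compound 1 gives 1300 nM, which is the second highest of the three numbers. Its nearest neighbour is compound 2, and the step of a 1.3-fold higher number from compound 1 to compound 2 (0.12 log units; within the scatter) is within the scatter, so these two values are treated as equivalent. Furthest from it stands compound 3, which gives 300 nM, a markedly lower number, though no single-point step between these two compounds is defined.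

Compound 4, `COc1cc(-c2cc(/C=C/C(=O)c3ccc(F)c(F)c3)[nH]n2)cc(OC)c1OC`, has not yet been measured in this assay. It differs from compound 1 by 3,4-difluorophenyl in place of 4-aminophenyl on a carbonyl carbon.

Going by the values given here, no measured step concerns the carbonyl-side ring. Among the compounds with values here, the only step recorded, from compound 1 to compound 2, changes the other ring and lies within the scatter, so it does not inform the present change. The pair compound 2 and compound 3 shows that swapping the carbonyl-side ring can move the number well beyond the scatter, but in which direction a change to 3,4-difluorophenyl moves it cannot be inferred from these three values. The expectation is therefore a wide one, centred near compound 1: the step of a 1.2-fold lower number from compound 1 to compound 4 (0.07 log units; within the scatter) is estimated to be small. For compound 4 the estimate is 1100 nM, within a range from 300 nM to 4000 nM.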

Compound 4, concentration for 50% growth inhibition: 3760 nM
Beside the measured number, compound 4's estimate is 3.4-fold (0.53 log units) below it; measured number inside the range.
By their numbers in this assay, from the lowest: compound 3; then compounds 1 and 2 (each within the scatter of the next); then compound 4.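

In this assay the replacement of 4-aminophenyl by 3,4-difluorophenyl on the carbonyl carbon gives a 2.9-fold higher number from compound 1 to compound 4 (0.46 log units; beyond the scatter) and so marks the carbonyl-side ring of the core of compound 1 as a place where a single change moves growth inhibition, here towards weaker inhibition. Going by these compounds alone, the one earlier step on this core, a 1.3-fold higher number from compound 1 to compound 2 (0.12 log units; within the scatter) on the other ring, gave no such reading. On this core, 4-aminophenyl is therefore the better of the two groups tried at this position, although the change removes the amine and introduces the two fluorines in one move, so the step cannot be assigned to either part.

On these data alone, whether the loss follows from the missing amine or from the added fluorines stays open, and unsubstituted phenyl on the same core would separate the two, while a hydroxyl group or an acetamide in place of the amine would show how much of that group the position needs. Nothing available on these compounds accounts for the size or direction of this step.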